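Phenylethyl Amide Against Methyl on Two Urea Cores

The source may hold more compounds than are shown below. What is called first, only, known or untested is meant among the compounds shown, and "the series" means these compounds.

Of the compounds shown here, three have been measured in a functional assay on MX1 cells (Homo sapiens) for inhibition, read by MTT assay, with a stated time of 120 h; a higher number here means a weaker inhibitor, a lower number a stronger inhibitor.
Compound 1 `CC(NC(=O)c1cccc(-c2ccc(NC(=O)Nc3ccc(Cl)c(C(F)(F)F)c3)cc2)c1)c1ccccc1` gives 5240 nM.
Compound 2 `CNC(=O)c1cccc(-c2ccc(NC(=O)Nc3ccc(Cl)c(C(F)(F)F)c3)cc2)c1` gives only a limit of the assay, > 50000 nM.
Compound 3 `CNC(=O)/C=C(\C)c1ccc(NC(=O)Nc2ccc(Cl)c(C(F)(F)F)c2)cc1` also gives only a limit of the assay, > 50000 nM.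

Compounds 2 and 1 differ in one place, (1-phenylethyl in place of methyl on an amide-type nitrogen). That change produced an at least 9.5-fold lower number from compound 2 to compound 1 (0.97 log units; beyond the scatter). The cores of compound 2 and compound 3 differ as well, (1-methyl-2-(methylcarbamoyl)ethenyl in place of 3-(methylcarbamoyl)phenyl on an aromatic carbon), but the step that the two limits leave unreadable from compound 2 to compound 3 cannot be sized because the limit of > 50000 nM in this assay, at which 2 of the 3 values shown sit, holds both of those values.

Compound 4 `C/C(=C\C(=O)NC(C)c1ccccc1)c1ccc(NC(=O)Nc2ccc(Cl)c(C(F)(F)F)c2)cc1` has not yet been measured. It differs from compound 3 by 1-phenylethyl in place of methyl on an amide-type nitrogen, the same change that separates compound 2 from compound 1, made at the same place.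

Among the compounds with values here, the step from compound 3 to compound 4 is expected to be about an at least 5.5-fold lower number from compound 3 to compound 4 (0.74 log units; beyond the scatter), an expectation resting only on an at least 9.5-fold lower number from compound 2 to compound 1 (0.97 log units; beyond the scatter), the single measured instance of this change, with no information on how the core of compound 3 itself behaves. Compound 4 is therefore estimated at 9000 nM, with a likely range from 2500 nM to 50000 nM.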

Compound 4, half-maximal inhibitory concentration: > 50000 nM
Compound 4 was reported as a limit; the forecaster's own chance of this, stated with the estimate: 30%; middle value at least 5.5-fold (0.74 log units) from the limit.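

Compound 4 also gives only a limit of the assay, so no step from compound 3 to compound 4 can be read, because both compounds rest on the same limit: the limit of > 50000 nM in this assay, at which 3 of the 4 values shown sit.

The compounds shown leave open whether 1-phenylethyl in place of methyl on an amide-type nitrogen changes the number at all on the core of compound 3.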